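A few compounds are considered here, and "the series" means these few. Any claim that something is new, unique, unknown or untested is made for them only; others in the source may bear on it.

Compound 3 `O=C(c1cccc(/C=C2\CC(=O)N(c3ccccc3)C2=O)c1)N1CCCC1` stands at the edge of what can be seen in an ADME assay on NCM460 cells (Homo sapiens) for cytotoxicity, read by MTT assay, with a stated time of 72 h; a lower number here means a stronger inhibitor, a higher number a weaker inhibitor: in this assay compound 3 gives > 100000 nM, which is a limit of the assay and not a number. Compound 1 `Cc1ccc(NC(=O)c2cccc(/C=C3\CC(=O)N(c4ccccc4)C3=O)c2)cc1` gives > 100000 nM, again a limit. Compound 2 `O=C(Nc1ccccc1)c1cccc(/C=C2\CC(=O)N(c3ccccc3)C2=O)c1` gives > 100000 nM, also a limit. Among the measured compounds shown here, because of the limit of > 100000 nM in this assay, at which 3 of the 3 values shown sit, none of the measured steps can be read: a step that the two limits leave unreadable from compound 1 to compound 2, a step that the two limits leave unreadable from compound 1 to compound 3 and a step that the two limits leave unreadable from compound 2 to compound 3 are all unreadable in size. Compound 4 `O=C(Nc1ccc(Cl)cc1)c1cccc(/C=C2\CC(=O)N(c3ccccc3)C2=O)c1` carries (4-chlorophenyl)amino in place of pyrrolidin-1-yl on a carbonyl carbon. The two changes at the same carbonyl carbon that were measured, from compound 1 and compound 2 to compound 3, left every value at the limit, so the step of a number no higher from compound 3 to compound 4 (the limit leaves the size open) is expected to show nothing beyond the scatter. Compound 4 is therefore estimated at 100000 nM, within 50000 nM to 300000 nM.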

Compound 4, half-maximal inhibitory concentration: > 100000 nM
Compound 4 gave a limit, no number (the forecaster's own chance of this, stated with the estimate: 85%); the middle value lies on the limit itself.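

No step from compound 1, compound 2 or compound 3 to compound 4 can be read, because all four compounds stand at a limit and not at a number: the limit of > 100000 nM in this assay, at which 4 of the 4 values shown sit.

Whether any of these compounds differs from the others in this assay stays open.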